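A few compounds are considered here, and "the series" means these few. Any claim that something is new, unique, unknown or untested is made for them only; others in the source may bear on it.

Measured so far:
Compound 1, `COc1cc(/C(Cl)=C/C=C(\C#N)C(=O)c2c[nH]c3ccccc23)cc(OC)c1OC`, gives 73.3%.
Compound 2, `N#C/C(=C\C=C(/Cl)c1ccc(Br)cc1)C(=O)c1c[nH]c2ccccc12`, gives 76.7%.
Compound 3, `COc1cc(/C(Cl)=C/C=C(\C#N)C(=O)c2c(C)[nH]c3ccccc23)cc(OC)c1OC`, gives 74.2%.

These values come from a functional assay for inhibition, read by Griess assay, with a stated time of 150 min, tested at 1 mM; on this read-out lower numbers stand for less inhibition and higher numbers for more inhibition at the one concentration tested (going by the name of the read-out). Compound 1 and compound 3 share a core and differ by one change, (methyl in place of hydrogen on an aromatic carbon). That change made a step of a number 0.9 percentage points higher from compound 1 to compound 3 (within the scatter). Compound 2 is built on a different core; how the two cores differ is not broken down here. Compound 4, `Cc1[nH]c2ccccc2c1C(=O)/C(C#N)=C/C=C(\Cl)c1ccc(Br)cc1`, has not yet been measured. Among the compounds with values here, it differs from compound 2 by methyl in place of hydrogen on an aromatic carbon, the same kind of change at a place described in the same words, so the step from compound 1 to compound 3 is the only guide. Because that step, a number 0.9 percentage points higher from compound 1 to compound 3 (within the scatter), stayed within the scatter, the expected step is also small: a number 0.3 percentage points higher from compound 2 to compound 4 (within the scatter). On this basis compound 4 is estimated to give 77%, most likely between 67% and 87%.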

Compound 4, a percentage reported as inhibition, at one concentration (the size of the read-out at that concentration, not a potency): 78.3%
Compound 4: the middle estimate sits 1.3 percentage points below what was measured, and the stated range covers the measured number.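

In this assay methyl in place of hydrogen gives a number 1.6 percentage points higher from compound 2 to compound 4 (within the scatter) on the core of compound 2. Set beside the earlier step, the change carries over from one core to the other with no difference that can be told apart: the same change on two cores in this assay, a number 0.9 percentage points higher (within the scatter) from compound 1 to compound 3 and a number 1.6 percentage points higher (within the scatter) from compound 2 to compound 4, 0.7 percentage points apart, within the scatter of two such steps. This shows only that adding the methyl leaves the reading within the scatter on these two cores; it does not show that the methyl raises inhibition, nor that other cores would behave the same way.

The compounds shown carry only hydrogen or methyl at this place. On these data alone, what a longer chain such as ethyl, an amine or a carboxylic acid would do there stays open.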